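The source may report more compounds than this note shows. Statements on the series, on what has been measured and on what is new or still open speak of the compounds shown alone.

Measured compounds and their values in an in vitro functional assay on HEK285-7 cells for antagonist activity at prostaglandin D2 receptor 2 (Homo sapiens), read by BRET and beta-arrestin recruitment; a higher number here means a weaker inhibitor, a lower number a stronger inhibitor:

compound 1 `O=C(O)Cc1sc(C(c2ccc(F)cc2)c2ccc(F)cc2)nc1-c1ccccc1`: 240 nM
compound 2 `O=C(O)Cc1sc(C(c2ccc(F)cc2)c2ccc(F)cc2)nc1-c1cc(F)cc(F)c1`: 340 nM
compound 3 `CS(=O)(=O)Nc1cccc(-c2nc(C(c3ccc(F)cc3)c3ccc(F)cc3)sc2CC(=O)O)c1`: 370 nM

Compound 3 carries the highest number of the three, but both steps leading to it lie within the scatter: a 1.5-fold higher number from compound 1 to compound 3 (0.19 log units; within the scatter) and a 1.1-fold higher number from compound 2 to compound 3 (0.04 log units; within the scatter). The three numbers therefore cannot be set in any order.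

Compound 4 `O=C(O)Cc1sc(C(c2ccc(F)cc2)c2ccc(F)cc2)nc1-c1cn[nH]c1` differs from compound 3 at the group on the aromatic carbon of the shared core: 1H-pyrazol-4-yl in place of 3-(methanesulfonamido)phenyl on an aromatic carbon. All three measured steps concern a change of the group at this same aromatic carbon, and each was within the scatter: a 1.4-fold higher number from compound 1 to compound 2 (0.15 log units; within the scatter), a 1.5-fold higher number from compound 1 to compound 3 (0.19 log units; within the scatter), a 1.1-fold higher number from compound 2 to compound 3 (0.04 log units; within the scatter). Among the measured compounds shown here, none of the measured changes, however, replaces the six-membered carbon ring by a five-membered ring with two hetero atoms; that kind of swap has no precedent among the three compounds. On the steps that exist, no change beyond the scatter is expected in this assay, and the estimated step is a 1.1-fold lower number from compound 3 to compound 4 (0.02 log units; within the scatter). For compound 4 the expected value in this assay is 350 nM, with a deliberately wide range from 120 nM to 1100 nM because the ring type itself changes.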

Compound 4, half-maximal inhibitory concentration: 220 nM
Compound 4: middle estimate off by 1.6-fold (0.20 log units), on the high side; measured number inside the range.
By their numbers in this assay, from the lowest: compounds 4, 1, 2 and 3 (each within the scatter of the next).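

In this assay the aromatic carbon next to the ring nitrogen now proves open to a five-membered aromatic ring with 2 hetero atoms as well as to six-membered aromatic rings of carbon only, with 1H-pyrazol-4-yl giving a 1.7-fold lower number from compound 3 to compound 4 (0.23 log units; within the scatter) and a 1.5-fold lower number from compound 2 to compound 4 (0.19 log units; within the scatter) and a 1.1-fold lower number from compound 1 to compound 4 (0.04 log units; within the scatter). The earlier compounds shown here varied only the substituents on a six-membered carbon ring, whereas this change alters the ring type and takes the group from 11 heavy atoms in 3-(methanesulfonamido)phenyl to 5 heavy atoms without moving the number beyond the scatter against any of the three. No measured information on these groups is available to account for this flat picture.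

Still open, as far as these compounds go, is whether a group with no aromatic ring at this carbon, such as a piperidine ring or a simple amine, or a pyrazole with a methyl group in place of the hydrogen on its ring nitrogen, would stay within the same narrow band. From the compounds shown here alone, all four compounds also share the carboxymethyl group and the large group, so the effect of an amide in place of the carboxylic acid remains open.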